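The compounds below may be only part of what the source reports. "The series", "measured", "known", "first", "only" and "open" are said of these compounds alone.

Working notes on the series. In a functional assay for antagonist activity at 5-hydroxytryptamine receptor 4 (Cavia porcellus) (on this read-out lower numbers stand for lower potency and higher numbers for higher potency (the scale is a negative logarithm)), compound 1 `CN1CCN(CNC(=O)n2c(=O)n(C3CC3)c3ccccc32)CC1` gives 6.19 and compound 2 `CCN1CCN(CCNC(=O)n2c(=O)n(C(C)C)c3ccccc32)CC1` gives 6.62; the two values stand apart by more than the usual scatter, though the structures differ in several places at once, so no single change can be read from them. Compound 3 `CN1CCN(CCNC(=O)n2c(=O)n(C)c3ccccc32)CC1` sits at a limit of this assay, with a reading of < 6 rather than a number. For the measured compounds named here, it is the one value of the three that rests at that limit (the limit of < 6 in this assay, at which 1 of the 3 values shown sits), so compound 3 is the only member of the series for which no potency figure exists.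

Compound 4 `CCCn1c(=O)n(C(=O)NCCN2CCN(C)CC2)c2ccccc21` is not yet measured. From compound 3 it differs by ethyl in place of hydrogen on a saturated chain carbon bound to an aromatic nitrogen. Compound 2, which carries a larger branched group at the same aromatic nitrogen, gives 6.62. Compound 3, with only a methyl there, rests at the limit of this assay. A step upward is therefore expected. The step from compound 3 to compound 4 in this assay is expected to be a number at least 0.40 log units higher from compound 3 to compound 4 (beyond the scatter), clearly beyond the scatter. Compound 4 is therefore estimated to give 6.4, within a range from 5.8 to 7.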

Compound 4, negative logarithm of the antagonist equilibrium constant: < 6
Compound 4: a limit, no number (the forecaster's own chance of this, stated with the estimate: 20%); at least 0.40 log units between middle value and limit.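

No step from compound 3 to compound 4 can be read, because both compounds rest at the same limit and neither gives a number: the limit of < 6 in this assay, at which 2 of the 4 values shown sit.

The compounds shown leave open whether methyl to propyl, on a saturated chain carbon bound to an aromatic nitrogen, changes potency at all in this assay, and by how much.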